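This account rests on a few compounds, and the source may have more. Where it says the series, first, only, none or still open, it means among the compounds named here.

Compound 3 `COc1ccc(COCC(Cn2ccnc2)OCCCCCCC(=O)O)cc1` sits at the top of the numbers in a functional assay on a cell-free system (plasma) for inhibition of Thromboxane-A synthase (Homo sapiens); a lower number here means a stronger inhibitor, a higher number a weaker inhibitor: compound 3 gives 1890 nM. The nearest measured compound is compound 1 `COc1ccc(COCC(Cn2ccnc2)OCCCCC(=O)O)cc1`, which in this assay gives 730 nM; the step of a 2.6-fold higher number from compound 1 to compound 3 (0.41 log units; beyond the scatter) is modest. Furthest away is compound 2 `CCOC(=O)CCCCCOC(COCc1ccc(OC)cc1)Cn1ccnc1`, which in this assay gives 120 nM; the step of a 16-fold higher number from compound 2 to compound 3 (1.20 log units; beyond the scatter) is large.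

Compound 4 `CCOC(=O)CCCCCCOC(COCc1ccc(OC)cc1)Cn1ccnc1` differs from compound 3 by ethyl in place of hydrogen on an oxygen next to a carbonyl group, the carboxy end becoming an ethoxycarbonyl end with the chain otherwise unchanged.

The step that bears most directly on this is a 6.1-fold lower number from compound 1 to compound 2 (0.78 log units; beyond the scatter), where the acid end of compound 1 gives way to the ester end of compound 2. The step of a 16-fold higher number from compound 2 to compound 3 (1.20 log units; beyond the scatter) runs the other way and combines the reverse of this change with a longer chain, so it sets an upper bound rather than a direct comparison. On this basis a lowering of the number in this assay of roughly the size seen between compound 1 and compound 2 is expected for compound 4, reading as a 6.3-fold lower number from compound 3 to compound 4 (0.80 log units; beyond the scatter). Compound 4 is therefore estimated at 300 nM in this assay, with a plausible range from 100 nM to 900 nM.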

Compound 4, half-maximal inhibitory concentration: 4000 nM
Estimate against measurement, compound 4: 13-fold (1.12 log units) below; measured number above the stated range.
By their numbers in this assay, from the lowest: compound 2; then compound 1; then compound 3; then compound 4.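

Within the data shown here, compound 4 gives the only clean acid-to-ester pair here: with the chain unchanged, ethyl in place of hydrogen on an oxygen next to a carbonyl group raises the number only modestly (a 2.1-fold higher number from compound 3 to compound 4 (0.33 log units; beyond the scatter)), so the earlier fall (a 6.1-fold lower number from compound 1 to compound 2 (0.78 log units; beyond the scatter)) cannot be credited to the ester alone, as that step also changes the chain. Between the two esters, where only the chain differs, the step is far larger (a 33-fold higher number from compound 2 to compound 4 (1.52 log units; beyond the scatter)), and the step that combines chain and ester changes also rises (a 5.5-fold higher number from compound 1 to compound 4 (0.74 log units; beyond the scatter)), so among these compounds the low number of compound 2 goes with its particular chain rather than with the ethoxycarbonyl end as such. Nothing on hand accounts for the size or direction of these steps.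

Among these compounds, still open is how a carboxylic acid behaves on the exact chain of compound 2, the one pair that would separate the end group from the chain at the lowest number. Also open, on these data alone, is whether a primary amide or a methyl ester at the chain end, or an ethyl ester on a shorter chain, would follow compound 2 or compound 4.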